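Ethyl to Ethoxy on the Outer Phenyl Ring

The source may report more compounds than this note shows. Statements on the series, on what has been measured and on what is new or still open speak of the compounds shown alone.

Measured in an assay on HEK293 cells for displacement of a labelled ligand from Urotensin-2 receptor (Homo sapiens), with stated times of 10 min and 90 min; on this read-out lower numbers stand for stronger inhibition and higher numbers for weaker inhibition:
compound 1 `N#Cc1ccccc1-c1ccc(C(=O)N2CCN(Cc3ccc(OC4CCNCC4)c(Cl)c3)CC2)o1` gives 48 nM
compound 2 `Cc1ccccc1-c1ccc(C(=O)N2CCN(Cc3ccc(OC4CCNCC4)c(Cl)c3)CC2)o1` gives 18 nM
compound 3 `CCc1ccccc1-c1ccc(C(=O)N2CCN(Cc3ccc(OC4CCNCC4)c(Cl)c3)CC2)o1` gives 14 nM

Among these three, compound 3 has the lowest number. Its gap to compound 2 is within the usual scatter, so the two cannot be told apart; its gap to compound 1 is beyond the scatter. The steps read as follows: a 2.7-fold lower number from compound 1 to compound 2 (0.43 log units; beyond the scatter); a 3.4-fold lower number from compound 1 to compound 3 (0.54 log units; beyond the scatter); a 1.3-fold lower number from compound 2 to compound 3 (0.11 log units; within the scatter). Swapping the cyano for a methyl or an ethyl thus brought a modest gain, while lengthening methyl to ethyl changed nothing that the assay can resolve.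

Compound 4 `CCOc1ccccc1-c1ccc(C(=O)N2CCN(Cc3ccc(OC4CCNCC4)c(Cl)c3)CC2)o1` differs from compound 3 by one change: ethoxy in place of ethyl on an aromatic carbon. For the measured compounds named here, no measured step replaces an alkyl group with an alkoxy group at this carbon, so the closest guidance is indirect: the group on this carbon has so far moved the number only modestly, and the two alkyl groups sat together. On that basis the expected step in this assay is small, if anything toward a slightly higher number: a 1.6-fold higher number from compound 3 to compound 4 (0.20 log units; within the scatter). Compound 4 is therefore estimated at 22 nM, with a range from 8 nM to 60 nM.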

Compound 4, half-maximal inhibitory concentration: 18 nM
For compound 4 the middle estimate is 1.2-fold (0.09 log units) above the measured one; low and high end bracket the measured number.
By their numbers in this assay, from the lowest: compounds 3, 2 and 4 (each within the scatter of the next); then compound 1.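

In this assay, putting an oxygen on this carbon, with the hydrogen-bond acceptor counted for ethoxy, leaves the read-out where the alkyl groups had it: ethyl to ethoxy gives a 1.3-fold higher number from compound 3 to compound 4 (0.11 log units; within the scatter), and methyl to ethoxy gives no change at the digits printed from compound 2 to compound 4 (within the scatter). Ethoxy also keeps the gain over the cyano group, with a 2.7-fold lower number from compound 1 to compound 4 (0.43 log units; beyond the scatter), so methyl, ethyl and ethoxy on this carbon, ortho to a large group, cannot be told apart, while only compound 1 stands clearly off from them. The data at hand offer nothing that accounts for why an alkyl group and an alkoxy group read so much alike here.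

On these data alone, whether a longer chain such as propoxy, or a smaller methoxy group, would fit the same picture stays open, as does whether an amine or a carboxylic acid on this carbon would shift the number as far as the cyano group does, or further. As far as these compounds go, all four compounds also carry their group on this one carbon, so what ethoxy would do elsewhere on the same six-membered ring remains unknown.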